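The source may report more compounds than this note shows. Statements on the series, on what has been measured and on what is new or still open speak of the compounds shown alone.

Compound 3 `CS(=O)(=O)OC1CCC(CN2CCN(c3cc(=O)c4cc(C(F)(F)F)cc([N+](=O)[O-])c4s3)CC2)CC1` is one of three close relatives tested in an ADME assay on Vero cells (Chlorocebus sabaeus) for cytotoxicity, read by MTT assay, with a stated time of 48 h; a higher number here means a weaker inhibitor, a lower number a stronger inhibitor. In this assay compound 3 gives only a limit, > 64 ug/mL. Compound 1 `CCCC(=O)OC1CCC(CN2CCN(c3cc(=O)c4cc(C(F)(F)F)cc([N+](=O)[O-])c4s3)CC2)CC1` likewise gives a limit, > 64 ug/mL. Compound 2 `O=C(OC1CCC(CN2CCN(c3cc(=O)c4cc(C(F)(F)F)cc([N+](=O)[O-])c4s3)CC2)CC1)C1CCCCC1` also gives a limit, > 64 ug/mL. The steps a step that the two limits leave unreadable from compound 1 to compound 2, a step that the two limits leave unreadable from compound 1 to compound 3 and a step that the two limits leave unreadable from compound 2 to compound 3 are all unreadable because of the limit of > 64 ug/mL in this assay, at which 3 of the 3 values shown sit. Compound 4 `O=C(OC1CCC(CN2CCN(c3cc(=O)c4cc(C(F)(F)F)cc([N+](=O)[O-])c4s3)CC2)CC1)c1ccncc1` differs from compound 3 by (pyridin-4-yl)carbonyl in place of methylsulfonyl on an oxygen on a saturated carbon. Going by the values given here, no measured step speaks to this exchange, and the earlier exchanges on the same oxygen left every value at the limit, so no shift beyond the scatter is expected, a step that the limit leaves unreadable from compound 3 to compound 4, and most likely another limit. The expected value for compound 4 in this assay is 80 ug/mL, estimated to lie between 40 ug/mL and 200 ug/mL.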

Compound 4, half-maximal inhibitory concentration: > 64 ug/mL
Compound 4: only a limit was reported (the forecaster's own chance of this, stated with the estimate: 85%); the middle value does not contradict the limit.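

Going by these compounds alone, compound 4 gives only a limit in this assay, so no step from compound 1, compound 2 or compound 3 to compound 4 can be read: the limit of > 64 ug/mL in this assay, at which 4 of the 4 values shown sit. The compounds shown leave open whether any exchange on this oxygen shifts the value in this assay at all.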